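Thromboxane synthase series: moving the bromo on the phenyl

The compounds below may be only part of what the source reports. "The series", "measured", "known", "first", "only" and "open" are said of these compounds alone.

Measured compounds in an assay (Equus caballus) for inhibition of Thromboxane-A synthase (Homo sapiens), using microsomes; on this read-out higher numbers stand for weaker inhibition and lower numbers for stronger inhibition:
compound 1 `O=C(O)CCCC/C=C(/c1ccc(Br)cc1)c1cccnc1`, 82 nM
compound 2 `CC(C)(CCCC/C=C(/c1ccccc1)c1cccnc1)C(=O)O`, 38 nM
compound 3 `COc1ccc(/C(=C/CCCCC(=O)O)c2cccnc2)cc1`, 80 nM

Compound 1 gives the highest of the three numbers in this assay. Compound 3 sits nearest, with a 1.0-fold lower number from compound 1 to compound 3 (0.01 log units; within the scatter). Compound 2 lies furthest, a step beyond the scatter to a lower number than compound 1.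

The next compound is compound 4 `O=C(O)CCCC/C=C(\c1cccnc1)c1ccccc1Br`. It differs from compound 1 by 2-bromophenyl in place of 4-bromophenyl on a double-bonded chain carbon bound to an aromatic carbon and a double-bonded chain carbon.

Going by the values given here, only one measured step alters the phenyl: the step from compound 1 to compound 3 , where methoxy in place of bromo on an aromatic carbon left the number unchanged within the scatter. Among the compounds with values here, no measured step moves a group from one aromatic carbon to another, so the change to compound 4 has no direct precedent. Within the data shown here, the one relevant step shows the phenyl tolerating a different group at the same place without a shift, and the bromine count is unchanged between compound 1 and compound 4. On that basis the step to compound 4 is expected to be a 1.3-fold higher number from compound 1 to compound 4 (0.13 log units; within the scatter), not beyond the scatter, with the range widened for the lack of a precedent. In this assay compound 4 is estimated at 110 nM, between 40 nM and 320 nM.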

Compound 4, half-maximal inhibitory concentration: 130 nM
For compound 4 the middle estimate is 1.2-fold (0.07 log units) below the measured one; low and high end bracket the measured number.
By their numbers in this assay, from the lowest: compound 2; then compounds 3, 1 and 4 (each within the scatter of the next).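

Moving the bromo gives the first measured change of place on this phenyl: in this assay, 2-bromophenyl in place of 4-bromophenyl gives a 1.6-fold higher number from compound 1 to compound 4 (0.20 log units; within the scatter) and leaves the two isomers indistinguishable. Read with a 1.0-fold lower number from compound 1 to compound 3 (0.01 log units; within the scatter), this shows that on the double-bonded chain carbon, the phenyl has now tolerated both a change of group and a change of the bromo's place without a step beyond the scatter, a statement limited to compounds 1, 3 and 4. Nothing measured here accounts for how little the place of the bromo matters in this assay.

Still open is whether the same tolerance holds for an amine or a nitrile in place of the bromo, since the only replacement shown is methoxy. Also open, on these data alone, is whether 2-bromophenyl would keep its standing on the dimethyl-substituted chain of compound 2, or on a longer chain ending in the carboxylic acid.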